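The source may report more compounds than this note shows. Statements on the series, on what has been measured and on what is new or still open speak of the compounds shown alone.

Of the compounds shown here, three have so far been measured in a functional assay on HOP-92 cells (Homo sapiens) for inhibition; on this read-out lower numbers stand for stronger inhibition of growth and higher numbers for weaker inhibition of growth. Compound 1 `CC(=O)CC/C=C(\C)CCC1=C(C)CCCC1(C)C` reaches only a limit of this assay, > 15000 nM. Compound 3 `C=C1CCCC(C)(C)C1(O)CC/C(C)=C/CC[C@]1(C)CC[C@@H]([C@@H](C)C(=O)OC)OO1` likewise gives only a limit, > 17500 nM. Going by the values given here, compound 2 `C=C1CCCC(C)(C)C1CC[C@]1(C)CC[C@@H]([C@@H](C)C(=O)O)OO1` is the single compound with a true number, 6630 nM, so it stands alone among the three and no ordering can be read from them. Compound 4 `C=C1CCCC(C)(C)C1CC[C@@]1(C)CC[C@H]([C@@H](C)C(=O)O)OO1` is not yet measured; it differs from compound 2 as follows: the two compounds have the same atoms and bonds; at least one stereo element is drawn with a configuration in one of them and without one in the other: 2 of 4 stereo elements differ; a stereocentre at a saturated ring carbon is drawn R in compound 2 and S in compound 4; a stereocentre at a saturated ring carbon is drawn S in compound 2 and R in compound 4. Among the compounds with values here, no step between measured compounds is available, so the size of this change is open; it may stay within the scatter or weaken inhibition. Compound 4 is expected to give 9000 nM, between 3000 nM and 30000 nM, an estimated step of a 1.4-fold higher number from compound 2 to compound 4 (0.13 log units; within the scatter).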

Compound 4, concentration for 50% growth inhibition: 2230 nM
The estimate for compound 4 lay 4.0-fold (0.61 log units) above the measured number, and the stated range ends above it.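

In this assay, changing only the two stereocentres at saturated ring carbons, with atoms and bonds the same, gives a 3.0-fold lower number from compound 2 to compound 4 (0.47 log units; beyond the scatter). Going by these compounds alone, the earlier compounds offered no step, so this is the first sign that configuration at these carbons matters, here towards stronger inhibition of growth. The step can be tied to stereochemistry alone, because nothing else separates the pair: the fact that one of compounds 2 and 4 is drawn with a defined configuration and the other without, at the place where they differ

Whether either stereocentre alone accounts for the step stays open. So does whether the same change would hold with an amide in place of the carboxylic acid.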